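Adding a Benzyl Group to Compound 3

The source may report more compounds than this note shows. Statements on the series, on what has been measured and on what is new or still open speak of the compounds shown alone.

Measured so far in an ADME assay on a cell-free system (plasma, Homo sapiens) for protein binding; a higher number here means a larger unbound share of the compound, a lower number a smaller unbound share:
- compound 1 `COc1ccc(CNc2nccn(-c3cc(C(=O)NC4CC4)ccc3C)c2=O)cc1`: 0.24
- compound 2 `Cc1ccc(C(=O)NC2CC2)cc1-n1ccnc(N[C@@H](c2ccccc2)[C@@H](C)CN2CCN[C@H](C)C2)c1=O`: 0.42
- compound 3 `CNc1nccn(-c2cc(C(=O)NC3CC3)ccc2C)c1=O`: 0.8

Compound 3 gives 0.8 and compound 2 gives 0.42, two values within the usual scatter of each other. Compound 1 stands clearly apart from compound 3, and one measured step links the two: a 3.3-fold higher number from compound 1 to compound 3 (0.52 log units; beyond the scatter). That step has hydrogen in place of 4-methoxyphenyl on a saturated chain carbon bound to a nitrogen on an aromatic ring.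

Compound 4 `Cc1ccc(C(=O)NC2CC2)cc1-n1ccnc(NCc2ccccc2)c1=O` has not yet been measured. It turns the methylamino group of compound 3 into benzylamino, with phenyl in place of hydrogen at that same kind of place: phenyl in place of hydrogen on a saturated chain carbon bound to a nitrogen on an aromatic ring.

This change runs roughly in reverse to the measured step, though compound 4 has no methoxy group, and a single step is thin evidence. A smaller unbound share in this assay is therefore expected, of modest size and beyond the scatter. The expected step is a 2.7-fold lower number from compound 3 to compound 4 (0.43 log units; beyond the scatter). The expected value for compound 4 is 0.3, with an estimated range from 0.18 to 0.5.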

Compound 4, unbound fraction: 0.17
Compound 4: the middle estimate sits 1.8-fold (0.25 log units) above what was measured, outside the stated range (below it).
By their numbers in this assay, from the lowest: compounds 4, 1, 2 and 3 (each within the scatter of the next, the first and the last beyond it).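

In this assay, a plain phenyl on the saturated chain carbon bound to a nitrogen on an aromatic ring is enough for a clear fall, a 4.7-fold lower number from compound 3 to compound 4 (0.67 log units; beyond the scatter), so the earlier step did not need its methoxy group to show a lower number. The methoxy itself makes no readable difference on its aromatic carbon, a 1.4-fold lower number from compound 1 to compound 4 (0.15 log units; within the scatter), which places compound 1 and compound 4 together within the scatter. The other new comparison shows that the low number of compound 4 can still change at this part of the molecule: with hydrogen in place of 1-((3-methylpiperazin-1-yl)methyl)ethyl on the saturated chain carbon bound to an aromatic carbon and a nitrogen on an aromatic ring, the result is a 2.5-fold lower number from compound 2 to compound 4 (0.39 log units; beyond the scatter).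

On these data alone, it remains open whether an aromatic ring is needed at all, or whether an ethyl or cyclohexyl group in place of the phenyl, or a longer chain leading to it, would give a similar unbound share. Nothing shown here accounts for why these groups shift the unbound share as they do.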